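The source may hold more compounds than are shown below. What is called first, only, known or untested is meant among the compounds shown, and "the series" means these compounds.

In a functional assay on HepG2 cells (Homo sapiens) for cytotoxicity, read by CCK-8 assay (on this read-out lower numbers stand for stronger inhibition and higher numbers for weaker inhibition), compound 1 (`COc1ccc(NC(=O)c2ncc(-c3ccccc3)o2)cc1`) gives > 30000 nM, which is a limit and not a number. Compound 2 (`CCN(CC)c1ccc(NC(=O)c2ncc(-c3ccccc3)o2)cc1`) gives > 30000 nM, also a limit. Within the data shown here, the one measured step is a step that the two limits leave unreadable from compound 1 to compound 2, and the only evidence on it is the limit of > 30000 nM in this assay, at which 2 of the 2 values shown sit. Compound 3 (`COc1ccc(NC(=O)c2ncc(-c3ccc(O)cc3)o2)cc1`) differs from compound 1 by hydroxy in place of hydrogen on an aromatic carbon, phenyl to 4-hydroxyphenyl, a change at another place in the structure. With only a step that the two limits leave unreadable from compound 1 to compound 2 to go on, no step beyond the scatter is expected in this assay, in either direction. The estimated change is a number no higher from compound 1 to compound 3 (the limit leaves the size open). For compound 3 the expected value is 30000 nM, within an estimated range of 10000 nM to 60000 nM.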

Compound 3, half-maximal inhibitory concentration: 17300 nM
The estimate for compound 3 lay 1.7-fold (0.24 log units) above the measured number; measured number inside the range.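

Among these compounds, compound 3 carries the only value shown that is a number and not a limit, which makes this place on the phenyl the one where a change can be read at all: the limit of > 30000 nM in this assay, at which 2 of the 3 values shown sit. In this assay, hydroxy in place of hydrogen, para to a large group, gives an at least 1.7-fold lower number from compound 1 to compound 3 (0.23 log units; that floor lies within the scatter). That step is only a floor, and by itself it does not separate the two compounds.

On these data alone, whether an amine or a carboxylic acid at this same place would give a lower number stays open. So does whether hydroxy would give a similar step alongside the diethylamino group of compound 2.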